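Shared core: amide nitrogen ethylation and cytotoxicity

This account rests on a few compounds, and the source may have more. Where it says the series, first, only, none or still open, it means among the compounds named here.

Compound 2 `NC(=O)/C=C/[C@H]1C[C@@H](O)[C@@H](O)C1` sits at a limit in an ADME assay on S2 cells (Drosophila melanogaster) for cytotoxicity, read by MTT assay; on this read-out higher numbers stand for an effect only at larger amounts of compound and lower numbers for an effect already at smaller amounts: compound 2 reports > 250000 nM, a limit rather than a number. Compound 1 `CN(C)C(=O)/C=C/[C@H]1C[C@@H](O)[C@@H](O)C1` likewise gives only a limit in this assay, > 250000 nM. Among the measured compounds shown here, the single measured step, a step that the two limits leave unreadable from compound 1 to compound 2, is thus unreadable, as the limit of > 250000 nM in this assay, at which 2 of the 2 values shown sit, shows both values resting on the same bound. Compound 3 `CCNC(=O)/C=C/[C@H]1C[C@@H](O)[C@@H](O)C1` differs from compound 2 by ethyl in place of hydrogen on an amide-type nitrogen. For the measured compounds named here, no measured step bears on this change; with compound 2 at a limit, no shift beyond the scatter can be anticipated, and the step that the limit leaves unreadable from compound 2 to compound 3 is expected to remain unreadable. Compound 3 is estimated at 300000 nM, within 100000 nM to 1000000 nM, most likely again reported only as a limit.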

Compound 3, half-maximal effective concentration: > 250000 nM
Compound 3 gave a limit, no number (the forecaster's own chance of this, stated with the estimate: 85%); the middle value is on the limit's open side.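

No step among compound 1, compound 2 and compound 3 can be read in this assay, because all three rest on the same limit: the limit of > 250000 nM in this assay, at which 3 of the 3 values shown sit.

As far as these compounds go, whether any substituent on the amide nitrogen of the shared core changes cytotoxicity remains open.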